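From 3-chlorobenzyl to phenethyl: an untested step

A few compounds are considered here, and "the series" means these few. Any claim that something is new, unique, unknown or untested is made for them only; others in the source may bear on it.

Values in a functional assay on A2780 cells (Homo sapiens) for antiproliferative activity, read by resazurin assay, with a stated time of 72 h; on this read-out higher numbers stand for weaker inhibition and lower numbers for stronger inhibition:
- Compound 1 `CN(Cc1ccccc1)C(=O)c1cc2c(Cc3cccc(Cl)c3)n[nH]c2cc1O`: 410 nM
- Compound 2 `CN(Cc1ccccc1Br)C(=O)c1cc2c(Cc3cccc(Cl)c3)n[nH]c2cc1O`: 130 nM
- Compound 3 `CN(Cc1ccc(CNS(C)(=O)=O)cc1)C(=O)c1cc2c(Cc3cccc(Cl)c3)n[nH]c2cc1O`: 570 nM
- Compound 4 `CN(Cc1ccccc1)C(=O)c1cc2c(CCc3ccccc3)n[nH]c2cc1O`: not yet measured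

Compound 1 gives 410 nM in this assay and is the reference for both measured steps. One is a 3.2-fold lower number from compound 1 to compound 2 (0.50 log units; beyond the scatter) and the other is a 1.4-fold higher number from compound 1 to compound 3 (0.14 log units; within the scatter). Compound 1 thus cannot be told apart from compound 3, while compound 2 gives the lowest number of the three.

Compound 4 differs from compound 1 in one place: benzyl in place of 3-chlorophenyl on a saturated chain carbon bound to an aromatic carbon. Cut one bond further out, the same change reads 3-chlorobenzyl to phenethyl. Among the compounds with values here, neither measured step touches this place, and no measured compound lacks the 3-chlorobenzyl group. The two steps therefore serve only as a rough gauge of how far one change has moved the number in this small set. A modest change is expected, and its upward direction is a weakly supported guess. The expected step is a 1.6-fold higher number from compound 1 to compound 4 (0.20 log units; within the scatter) and may well stay within the scatter. For compound 4 the estimated value is 650 nM, with an expected range from 200 nM to 2100 nM.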

Compound 4, half-maximal inhibitory concentration: 4600 nM
Beside the measured number, compound 4's estimate is 7.1-fold (0.85 log units) below it; the whole stated range lies below it.
By their numbers in this assay, from the lowest: compound 2; then compounds 1 and 3 (each within the scatter of the next); then compound 4.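

In this assay, replacing 3-chlorobenzyl with phenethyl gives an 11-fold higher number from compound 1 to compound 4 (1.05 log units; beyond the scatter) and so shows that this position, which neither earlier step touched, can move the number much further than the bromo step did, a 3.2-fold lower number from compound 1 to compound 2 (0.50 log units; beyond the scatter). The leaving and entering groups match in their counts of heavy atoms, hydrogen-bond donors and hydrogen-bond acceptors, and neither carries a net charge, so those counts alone do not track this loss of activity. No measurement available here explains why the number rises so far.

The change removes the chlorine and lengthens the chain in a single step, so the compounds shown cannot separate these two differences; an unsubstituted benzyl group or a 3-chlorophenethyl group at this position would pull them apart. Also open, from the compounds shown here alone, is how a longer chain such as 3-phenylpropyl would read out here, and whether the bromo group that lowers the number in compound 2 would do the same alongside phenethyl.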